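The compounds below may be only part of what the source reports. "The series", "measured", "known", "first", "only" and "open" are said of these compounds alone.

Working notes on the series.

Among the measured compounds shown here, in an assay on HeLa cells for inhibition of sphingosine-1-phosphate transporter SPNS2 (Mus musculus), read by LC-MS, tested at 2 uM (a higher number here means more inhibition at the concentration tested (going by the name of the read-out), a lower number less inhibition), compound 3 `CCCCCCCCCCc1ccc(-c2noc(C3CCNC3)n2)cc1` gives 26%, the lowest of the three numbers so far. Compound 1 `CCCCCCCCCCc1ccc(-c2noc(CCCCN)n2)cc1` gives 55% and compound 2 `CCCCCCCCCCc1ccc(-c2noc(CC3CNC3)n2)cc1` gives 63% in this assay; the two steps onto compound 3 are a number 29 percentage points lower from compound 1 to compound 3 (beyond the scatter) and a number 37 percentage points lower from compound 2 to compound 3 (beyond the scatter), while a number 8 percentage points higher from compound 1 to compound 2 (within the scatter).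

Compound 4 `CCCCCCCCCCc1ccc(-c2noc([C@@H]3CC[C@H](N)C3)n2)cc1` differs from compound 3 by 3-aminocyclopentyl in place of pyrrolidin-3-yl on an aromatic carbon. Both measured steps onto compound 3 run from a group whose nitrogen sits outside a ring, or in a four-membered ring, to the pyrrolidin-3-yl group and lower this assay, one modestly and one by a large margin. For the measured compounds named here, compound 4 again carries its nitrogen outside the ring, so the change is expected to recover part of that loss; the step is estimated as a number 24 percentage points higher from compound 3 to compound 4 (beyond the scatter), with no measured pair reporting on the two defined stereocentres. For compound 4 the estimate in this assay is 50%, in the range 30% to 70%.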

Compound 4, a percentage reported as inhibition, at one concentration (the size of the read-out at that concentration, not a potency): 38%
Compound 4: the middle estimate sits 12 percentage points above what was measured; low and high end bracket the measured number.
By their numbers in this assay, from the lowest: compound 3; then compound 4; then compounds 1 and 2 (each within the scatter of the next).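

In this assay the change from pyrrolidin-3-yl to 3-aminocyclopentyl gives a number 12 percentage points higher from compound 3 to compound 4 (beyond the scatter) on this aromatic carbon, so a nitrogen outside the five-membered ring recovers only part of the ground. The same group still gives a number 25 percentage points lower from compound 2 to compound 4 (beyond the scatter) and also a number 17 percentage points lower from compound 1 to compound 4 (beyond the scatter) here, so both five-membered rings set directly on this carbon, in compound 3 and compound 4, stand lower than the groups of compound 1 and compound 2. Nothing at hand gives a reason for these steps.

How far the two defined stereocentres of 3-aminocyclopentyl contribute stays open, since the compounds shown hold a single stereoisomer. Also open, from the compounds shown here alone, is whether a six-membered ring amine such as piperidin-4-yl on this carbon would stand with compound 3 and compound 4 or with compound 1 and compound 2.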